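The source may hold more compounds than are shown below. What is called first, only, known or untested is meant among the compounds shown, and "the series" means these compounds.

Measured so far:
compound 1 `COc1ccc(-c2nc(C)c(C(=O)CSc3nc(-c4ccc(Cl)cc4)c(C#N)c(=O)[nH]3)s2)cc1`: 102%
compound 2 `Cc1nc(-c2ccccc2)sc1C(=O)CSc1nc(-c2cccc(Cl)c2)c(C#N)c(=O)[nH]1`: 86.9%

In a functional assay on U-87MG ATCC cells for antiproliferative activity against U-87 MG (Homo sapiens), read by MTT assay, with a stated time of 48 h, tested at 5 uM (on this read-out lower numbers stand for a stronger effect and higher numbers for a weaker effect at the one concentration tested), compound 1 gives 102%, and compound 2 gives 86.9%. Of the two numbers, compound 2 stands lowest, and the gap to compound 1 lies beyond the scatter. Compound 3 `COc1ccc(-c2nc(C)c(C(=O)CSc3nc(-c4cccc(Cl)c4)c(C#N)c(=O)[nH]3)s2)cc1` differs from compound 2 by one change: methoxy in place of hydrogen on an aromatic carbon. No step of this kind has been measured among these compounds, so the expectation rests on the two values alone: a small rise in this assay, of a size that may fall within the scatter, is expected, a number 6.1 percentage points higher from compound 2 to compound 3 (within the scatter). Compound 3 is therefore estimated at 93%, within a range of 78% to 106%.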

Compound 3, a percentage reported as activity, at one concentration (the size of the read-out at that concentration, not a potency): 95.7%
For compound 3 the middle estimate is 2.7 percentage points below the measured one, within the range that was stated.
By their numbers in this assay, from the lowest: compounds 2, 3 and 1 (each within the scatter of the next, the first and the last beyond it).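

In this assay, the change from phenyl to 4-methoxyphenyl, at a position para to a large group, gives a number 8.8 percentage points higher from compound 2 to compound 3 (within the scatter), so methoxy on this ring does not shift the read-out beyond the scatter. The second single change, 3-chlorophenyl in place of 4-chlorophenyl, gives a number 6.3 percentage points lower from compound 1 to compound 3 (within the scatter), so it too stays inside the scatter. Nothing available explains either step.

The compounds shown leave open how an amine or a longer ethoxy chain would read at this position. They also leave open whether the methoxy step would hold with 4-chlorophenyl on the other ring.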